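Methyl capping of the hydroxypropynyl chain

The compounds below may be only part of what the source reports. "The series", "measured", "known", "first", "only" and "open" are said of these compounds alone.

Values in an ADME assay on L1210/0 cells (Mus musculus) for cytotoxicity, with a stated time of 48 h; on this read-out higher numbers stand for weaker inhibition and lower numbers for stronger inhibition:
- Compound 1 `O=c1[nH]c(=O)n([C@H]2C[C@H](O)[C@@H](CO)O2)cc1[N+](=O)[O-]`: 130 nM
- Compound 2 `O=c1[nH]c(=O)n([C@H]2C[C@H](O)[C@@H](CO)O2)cc1C#CCO`: > 200000 nM (a limit, not a number)

Compound 2 has no exact position on the scale, only (the limit of > 200000 nM in this assay, at which 1 of the 2 values shown sits). Compound 3 `COCC#Cc1cn([C@H]2C[C@H](O)[C@@H](CO)O2)c(=O)[nH]c1=O` differs from it by methyl in place of hydrogen on an oxygen on a saturated carbon, which reads as hydroxy to methoxy. Going by the values given here, the one measured step, an at least 1500-fold higher number from compound 1 to compound 2 (3.18 log units; beyond the scatter), is large, but it replaces nitro and leaves hydroxy to methoxy untested. Taking compound 2, with its limit of > 200000 nM, as the nearest reference, no step beyond the scatter is expected in this assay. The expected step is a number no higher from compound 2 to compound 3 (the limit leaves the size open). For compound 3 the estimate is 200000 nM, with an expected range of 40000 nM to 400000 nM.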

Compound 3, half-maximal inhibitory concentration: > 200000 nM
Compound 3 was reported as a limit; the forecaster's own chance of this, stated with the estimate: 60%; the middle value lies on the limit itself.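

In this assay, compound 3 gives > 200000 nM, a limit and not a number, so methoxy in place of hydroxy does not bring the read-out to a measurable value. With 3-methoxyprop-1-yn-1-yl in place of nitro, the result is an at least 1500-fold higher number from compound 1 to compound 3 (3.18 log units; beyond the scatter), so the large gap to the nitro compound remains without the free hydroxy. The step between the two alkynes cannot be read, because both sit at the same limit: the limit of > 200000 nM in this assay, at which 2 of the 3 values shown sit.

From the compounds shown here alone, the order of compound 2 and compound 3 stays open. Also open, going by these compounds, is whether an amine or a longer chain in place of nitro on the aromatic carbon would give a value within the measurable range.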